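This account rests on a few compounds, and the source may have more. Where it says the series, first, only, none or still open, it means among the compounds named here.

Measured so far in a physicochemical assay for solubility, in phosphate buffer, at pH 6.8; on this read-out lower numbers stand for lower solubility and higher numbers for higher solubility:
compound 2 `COc1ccc(C(=O)C2=C(O)C(=O)N(c3ccc(-c4ccon4)cc3)C2c2ccccc2OC)cc1` gives 34700 nM
compound 1 `CCC(CC)C1C(C(=O)c2ccc(OC)cc2)=C(O)C(=O)N1c1ccc(-c2ccon2)cc1` gives 2200 nM

Compound 2 stands highest of the two numbers; the nearest is compound 1, reached by a 16-fold higher number from compound 1 to compound 2 (1.20 log units; beyond the scatter). Compound 3 `COc1ccc(C(=O)C2=C(O)C(=O)N(c3ccc(-c4ccon4)cc3)C2c2ccccc2OCCO)cc1` carries the change (hydroxymethyl in place of hydrogen on a saturated chain carbon bound to an oxygen on an aromatic ring). Within the data shown here, no measured step touches this position: the only step available, from compound 1 to compound 2, changes the group on the saturated ring carbon and was large. The step to compound 3 is therefore expected to be small, a 1.4-fold higher number from compound 2 to compound 3 (0.16 log units; within the scatter), likely within the scatter or a modest rise. Compound 3 is estimated at 50000 nM, range 17000 nM to 150000 nM.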

Compound 3, solubility: > 50000 nM
Compound 3 gave a limit, no number; the forecaster's own chance of this, stated with the estimate: 5%; the middle value lies on the limit itself.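

Compound 3 gives > 50000 nM in this assay, a limit and not a number. Against pentan-3-yl, 2-(2-hydroxyethoxy)phenyl keeps a large gap: an at least 22-fold higher number from compound 1 to compound 3 (1.35 log units; beyond the scatter). Methoxy to 2-hydroxyethoxy, the only change shown at this position, reads as an at least 1.4-fold higher number from compound 2 to compound 3 (0.15 log units; that floor lies within the scatter), so the number does not drop, though the true size of the step stays hidden: the limit of > 50000 nM in this assay, at which 1 of the 3 values shown sits.

From the compounds shown here alone, how far compound 3 lies past the limit stays open, so whether it truly separates from compound 2 cannot be read. Also open, going by these compounds, is how an amine or a carboxylic acid in place of the hydroxymethyl, or a longer chain, would read in this assay.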